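This account rests on a few compounds, and the source may have more. Where it says the series, first, only, none or still open, it means among the compounds named here.

Measured so far:
Compound 1 `N#CC1=C(NCC(=O)N2CCOCC2)N(c2ccccc2)C(=O)N2CCCCC(N3CCCC3)C12`: 69.8%
Compound 2 `N#CC1=C(NCN2CCCCC2)N(c2ccccc2)C(=O)N2CCCCC(N3CCCC3)C12`: 36.9%

In a functional assay on the whole organism (strain albino) for inhibition, with Rattus norvegicus as the target, read by paw edema, with stated times of 1 h and 2 h, at a dose of 20 mmol/kg by the intraperitoneal route (on this read-out lower numbers stand for less inhibition and higher numbers for more inhibition at the one dose given (going by the name of the read-out)), compound 1 gives 69.8% and compound 2 gives 36.9%. Going by the values given here, compound 2 therefore stands lowest of the two numbers, and the only measured step is a number 32.9 percentage points lower from compound 1 to compound 2 (beyond the scatter), a large one for a change on the chain bound to the amine nitrogen.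

Compound 3 `COc1ccc(/C=N/C2=C(C#N)C3C(N4CCCC4)CCCCN3C(=O)N2c2ccccc2)cc1` differs from compound 2 in a group of 10 heavy atoms (8 carbon, 1 nitrogen, 1 oxygen; one six-membered aromatic ring of carbon only) in place of a group of 8 heavy atoms (6 carbon, 2 nitrogen; one six-membered non-aromatic ring with 1 hetero atom), on a double-bonded ring carbon. Among the compounds with values here, no measured step touches this exact change; the one step that exists sits in the same region of the core and was large, so a change at the double-bonded ring carbon is expected to move the read-out noticeably, in a direction the data cannot fix. For compound 3 in this assay a middle value of 45% is expected. The range for compound 3 is estimated from 20% to 72%. The implied step is expected to be a number 8.1 percentage points higher from compound 2 to compound 3 (within the scatter).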

Compound 3, a percentage reported as inhibition, in the whole organism at one dose (the size of the read-out at that dose, not a potency): 71.6%
Estimate against measurement, compound 3: 26.6 percentage points below; the range from low to high includes it.
By their numbers in this assay, from the lowest: compound 2; then compounds 1 and 3 (each within the scatter of the next).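

In this assay, the double-bonded ring carbon now has a second measured change, and the group that enters there, with its six-membered aromatic ring of carbon only, gives a number 34.7 percentage points higher from compound 2 to compound 3 (beyond the scatter). Against the morpholine-bearing group of compound 1, the same group gives a number 1.8 percentage points higher from compound 1 to compound 3 (within the scatter), so two quite different groups at this position read alike, and only the ((piperidin-1-yl)methyl)amino group of compound 2 stands apart from them. No measurement offered here accounts for this difference.

From the compounds shown here alone, with only these groups at this position, it remains open whether the read-out depends on the aromatic ring, the double bond outside it, or neither. A simple amine or a carboxylic acid at the same ring carbon would help to separate these possibilities.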